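The source may hold more compounds than are shown below. What is called first, only, known or untested is meant among the compounds shown, and "the series" means these compounds.

In a functional assay on A549 cells (Homo sapiens) for antiproliferative activity, read by MTT assay, with a stated time of 24 h (on this read-out higher numbers stand for weaker inhibition and lower numbers for stronger inhibition), compound 1 `O=C(NNc1cccc(Cl)c1)c1ccc(NS(=O)(=O)c2cnc(O)nc2O)cc1` gives 7290 nM. Compound 2 `O=C(NNc1cccc(Cl)c1)c1cccc(NS(=O)(=O)c2cnc(O)nc2O)c1` gives 6640 nM and compound 3 `O=C(NNc1ccccc1F)c1ccccc1NS(=O)(=O)c1cnc(O)nc1O` gives 9610 nM; the three numbers lie within the scatter of one another, so compound 1 cannot be set apart from either of them. Compound 4 `O=C(NNC(=O)c1ccc(NS(=O)(=O)c2cnc(O)nc2O)cc1)c1ccc(F)cc1` has not been measured. It differs from compound 1 in one place: (4-fluorophenyl)carbonyl in place of 3-chlorophenyl on an amine nitrogen. Among the measured compounds shown here, no step of this kind between measured compounds is known, and none of the three measured compounds carries the entering group, so nothing in the data fixes the size of the move. The step of a 1.2-fold higher number from compound 1 to compound 4 (0.09 log units; within the scatter) is expected to be small, not beyond the scatter. The estimate for compound 4 in this assay is 9000 nM, within 3500 nM to 25000 nM.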

Compound 4, half-maximal inhibitory concentration: > 20000 nM
Compound 4 gave a limit, no number; the forecaster's own chance of this, stated with the estimate: 10%; at least 2.2-fold (0.34 log units) between middle value and limit.
By their numbers in this assay, from the lowest: compounds 2, 1 and 3 (each within the scatter of the next). At a limit, above all of these: compound 4.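

Among the compounds shown here, the change on the amine nitrogen gives an at least 2.7-fold higher number from compound 1 to compound 4 (0.43 log units; beyond the scatter), the first step at this place in this assay, and it shows that the read-out responds to (4-fluorophenyl)carbonyl in place of 3-chlorophenyl. The real size of the step stays unknown, since compound 4 gave only a limit: the limit of > 20000 nM in this assay, at which 1 of the 4 values shown sits.

The compounds shown do not separate the entering carbonyl from the change of halogen and ring position. Compound 4 alone cannot settle this; (3-chlorophenyl)carbonyl or plain 4-fluorophenyl on the same nitrogen would divide the two.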